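The compounds below may be only part of what the source reports. "The series", "measured", "known", "first", "only" and "open" are said of these compounds alone.

Measured so far in a functional assay on L02 cells (Homo sapiens) for inhibition, read by Griess assay, with stated times of 1 h and 24 h; on this read-out higher numbers stand for weaker inhibition and lower numbers for stronger inhibition: compound 1 `CCCc1nn(C)c2c(NC3CC3)nc(/C=C/c3nc(C)c(C)nc3C)nc12` gives 706000 nM, and compound 3 `COc1cc(/C=C/c2nc(N3CCCC3)c3sccc3n2)cc(OC)c1OC` gives 681000 nM. For compound 2 `Fc1ccc(CNc2nc(/C=C/c3ccco3)nc3ccsc23)cc1` the read-out is only a limit, > 1000000 nM, not a number (the limit of > 1000000 nM in this assay, at which 1 of the 3 values shown sits).

Compound 3 holds the lower of the two numbers, yet compound 1 sits within the usual scatter of it, so neither can be called stronger. Compound 4 `COc1cc(/C=C/c2nc(NCc3ccncc3)c3sccc3n2)cc(OC)c1OC` has not been measured. It differs from compound 3 in one place: ((pyridin-4-yl)methyl)amino in place of pyrrolidin-1-yl on an aromatic carbon. Among the compounds with values here, no measured pair shows this same change, so its effect is not known from these data. In this assay a small step in either direction, not clearly beyond the scatter, is expected. Compound 4 is estimated at 800000 nM, with a range from 300000 nM to 1000000 nM. This estimate implies an expected step of a 1.2-fold higher number from compound 3 to compound 4 (0.07 log units; within the scatter).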

Compound 4, half-maximal inhibitory concentration: 374000 nM
The estimate for compound 4 lay 2.1-fold (0.33 log units) above the measured number; the range from low to high includes it.
By their numbers in this assay, from the lowest: compounds 4, 3 and 1 (each within the scatter of the next). At a limit, above all of these: compound 2.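

In this assay, ((pyridin-4-yl)methyl)amino in place of pyrrolidin-1-yl on this aromatic carbon, next to the ring nitrogen, gives a 1.8-fold lower number from compound 3 to compound 4 (0.26 log units; within the scatter). This first pair at this position shows that a larger group, carrying an aromatic ring and a hydrogen-bond donor, leaves the number within the scatter. Nothing measured here bears on the reason for this small step.

As far as these compounds go, it remains open whether a morpholine or a dimethylamino group at this carbon would behave the same way. From the compounds shown here alone, it also remains open whether any group here can produce a step beyond the scatter.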